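Cytotoxicity of a Triazole Series: Phenyl to Chloromethyl Exchange

This account rests on a few compounds, and the source may have more. Where it says the series, first, only, none or still open, it means among the compounds named here.

The study gathers three triazole-based compounds tested in an ADME assay (MDM cells, Homo sapiens) for cytotoxicity, read by resazurin assay, with a stated time of 3 days (a lower number here means a stronger inhibitor, a higher number a weaker inhibitor), together with one that has not yet been run. In this assay compound 1 `O=C(Nn1c(COc2ccccc2C2=NOC(c3ccc(Cl)cc3Cl)C2)nnc1Sc1ccccc1)c1ccccc1` gives "not determined" (no result reported), and compound 3 `C/C=C/Sc1nnc(COc2ccccc2C2=NOC(c3ccc(Cl)cc3Cl)C2)n1NC(=O)c1ccccc1` gives "not determined" (no result reported), so neither of them has a result to report. Going by the values given here, compound 2 `CCCSc1nnc(COc2ccccc2C2=NOC(c3ccc(Cl)cc3Cl)C2)n1NC(=O)c1ccccc1` is therefore the only member with a number: in this assay compound 2 gives 14.8 ug/mL, and with no second value to set beside it, nothing can be said about how it ranks against its neighbours.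

Compound 4 `CCCSc1nnc(COc2ccccc2C2=NOC(c3ccc(Cl)cc3Cl)C2)n1NC(=O)CCl` is the unmeasured analogue. It differs from compound 2 in one place, chloromethyl in place of phenyl on a carbonyl carbon: the benzoyl becomes a (chloromethyl)carbonyl, so the benzamido of compound 2 reads as a ((chloromethyl)carbonyl)amino in compound 4. Among the compounds with values here, no measured pair in the set shows what such an exchange does, so the expectation rests on compound 2 alone.

Compound 4 is expected to lie somewhat lower than compound 2, with an estimated step of a 1.9-fold lower number from compound 2 to compound 4 (0.27 log units; within the scatter) in this assay. The estimated value for compound 4 is 8 ug/mL, within an expected range from 3 ug/mL to 25 ug/mL.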

Compound 4, half-maximal inhibitory concentration: 28.7 ug/mL
Compound 4: the middle estimate sits 3.6-fold (0.55 log units) below what was measured; measured number outside the range, above it.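

Going by these compounds alone, exchanging phenyl for chloromethyl on a carbonyl carbon gives the first readable step in this assay, a 1.9-fold higher number from compound 2 to compound 4 (0.29 log units; within the scatter). The six-membered aromatic ring leaves and only two heavy atoms enter, yet the printed step places compound 2 and compound 4 within the scatter of each other, so this pair does not separate the two groups at this position. Nothing measured here accounts for this result.

On these data alone, what remains open is whether an amine, a carboxylic acid or a longer chain in place of the chloromethyl on that carbonyl carbon would stay equally close to compound 2. A single pair also leaves open whether the same exchange would read alike with another group on the sulfur.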